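A few compounds are considered here, and "the series" means these few. Any claim that something is new, unique, unknown or untested is made for them only; others in the source may bear on it.

Of the compounds shown here, two have numbers so far in an assay on HEK-Blue hTLR8 cells for inhibition of Toll-like receptor 8 (Homo sapiens), read by colorimetric assay, with stated times of 1 h and 24 h; a higher number here means a weaker inhibitor, a lower number a stronger inhibitor. Compound 1, `CS(=O)(=O)c1nc(C2CCCCC2)cc(C(F)(F)F)n1`, gives 8500 nM in this assay. Compound 2, `Oc1cccc(CNc2nc(-c3ccco3)cc(C(F)(F)F)n2)c1`, gives 23000 nM in this assay, the higher of the two numbers; the gap between compound 2 and compound 1 is beyond the usual scatter of repeated measurements, so compound 2 is the weaker inhibitor of the pair.

Compound 3, `COc1cccc(CNc2nc(-c3ccco3)cc(C(F)(F)F)n2)c1`, has not yet been measured. It differs from compound 2 in one place: methyl in place of hydrogen on an oxygen on an aromatic ring, so that hydroxy becomes methoxy and 3-hydroxyphenyl becomes 3-methoxyphenyl. Among the measured compounds shown here, no pair of measured compounds shows this same change, so there is no measured step to lean on for its size or direction. With one hydrogen-bond donor lost and only a single carbon added, the expected step of a 1.1-fold higher number from compound 2 to compound 3 (0.04 log units; within the scatter) is small, most likely within the scatter, with a wide range allowed in either direction. On that basis compound 3 is estimated at 25000 nM in this assay, with a range from 8000 nM to 80000 nM.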

Compound 3, half-maximal inhibitory concentration: "not active" (no number reported)
The entry for compound 3 holds no number, and the estimate cannot be compared.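

Among the compounds shown here, compound 3 is recorded as "not active" in this assay with no number beside it, so no step from compound 2 to compound 3 can be read. The compounds shown leave open how far, and in which direction, the change from hydroxy to methoxy moves the number. No outside evidence bears on this result.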